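A few compounds are considered here, and "the series" means these few. Any claim that something is new, unique, unknown or untested is made for them only; others in the source may bear on it.

In a functional assay on MSTO-211H cells (Homo sapiens) for inhibition, read by trypan blue exclusion, with a stated time of 72 h (on this read-out lower numbers stand for stronger inhibition of growth and higher numbers for weaker inhibition of growth), compound 1 (`CCCn1c(-c2ccc(O)cc2)c(C)c2cc(O)ccc21`) gives 2900 nM and compound 2 (`Cc1c(-c2ccc(O)cc2)n(CCCOc2ccccc2)c2ccc(O)cc12`) gives 2400 nM, which places compound 1 level with compound 2 within the scatter. Compound 3 (`Cc1c(-c2ccc(O)cc2)[nH]c2ccc(O)cc12`) carries hydrogen in place of propyl on an aromatic nitrogen. Within the data shown here, the only measured step on that chain is a 1.2-fold lower number from compound 1 to compound 2 (0.08 log units; within the scatter), which adds to the propyl group and does not remove it, so it bears only loosely on this change. Among the measured compounds shown here, with no measured compound lacking that chain, the expected change is a modestly higher number, an estimated 1.4-fold higher number from compound 1 to compound 3 (0.14 log units; within the scatter). For compound 3 the estimated value is 4000 nM, with an expected range of 1400 nM to 12000 nM.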

Compound 3, concentration for 50% growth inhibition: > 20000 nM
Compound 3 ended at the assay's limit; the forecaster's own chance of this, stated with the estimate: 12%; middle value at least 5.0-fold (0.69 log units) away from the limit.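

With hydrogen in place of propyl on the aromatic nitrogen, this assay shows an at least 6.8-fold higher number from compound 1 to compound 3 (0.83 log units; beyond the scatter), so this position responds to losing its chain, which the earlier step could not show. That earlier step, a 1.2-fold lower number from compound 1 to compound 2 (0.08 log units; within the scatter), only showed that phenoxy on the chain end leaves the number within the scatter. Compound 3 stands at a limit of the assay and not at a number: the limit of > 20000 nM in this assay, at which 1 of the 3 values shown sits.

The compounds shown leave open whether a shorter chain, such as methyl or ethyl, is enough on this nitrogen. They also leave open whether an amine or a carboxylic acid on the propyl chain would be accepted as phenoxy is.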